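The compounds below may be only part of what the source reports. "The series", "measured", "known", "first", "only" and "open" are said of these compounds alone.

Measured compounds:
- compound 1 `O=C(O)c1ccc(N(C(=O)CCCCCBr)c2cccc(C(=O)O)c2)cc1` — "not determined" (no result reported) in an assay on isolated protein for binding affinity to E-selectin (Homo sapiens), read by ELISA, tested at 100 uM; a higher number here means more inhibition at the concentration tested (going by the name of the read-out), a lower number less inhibition
- compound 2 `CCCCCCCCCCOc1cccc(OCCCCCC(=O)N(Cc2ccc(C(=O)OC)cc2)c2ccc(C(=O)OC)cc2)c1` — 65% in this assay
- compound 3 `CCCCCCCCCCOc1cc(OCCCCCCCCCC)cc(OCCCCCC(=O)N(c2cccc(C(=O)O)c2)c2cccc(C(=O)O)c2)c1` — "not determined" (no result reported) in this assay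

Compound 3 therefore stands without a number of its own in this assay; the only figure in this series belongs to compound 2, which gives 65% in this assay, and compound 1 likewise lacks a result. Compound 4 `CCCCCCCCCCOc1cc(OCCCCCCCCCC)cc(OCCCCCC(=O)N(c2cccc(C(=O)O)c2)c2ccc(C(=O)O)c(C(=O)O)c2)c1` differs from compound 3 by carboxy in place of hydrogen on an aromatic carbon, that is, a 3-carboxyphenyl becomes a 3,4-dicarboxyphenyl while the two decyloxy chains and the amide linker are kept. Among the measured compounds shown here, since no pair of measured compounds in this set shows what such a change does in this assay, the size of the step from compound 3 to compound 4 cannot be read from the data; he expects it to fall within the usual scatter rather than beyond it, in either direction. Taking the result of compound 2 as the only anchor, compound 4 is estimated at 60% in this assay, with a range of 30% to 85%.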

Compound 4, a percentage reported as inhibition, at one concentration (the size of the read-out at that concentration, not a potency): 62%
For compound 4 the middle estimate is 2 percentage points below the measured one; low and high end bracket the measured number.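

Among the compounds shown here, compound 3 has no single number in this assay, so no step to compound 4 can be read from its 62%. From the compounds shown here alone, what carboxy in place of hydrogen on that ring does to inhibition stays open. No evidence bearing on this result is available.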